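The compounds below may be only part of what the source reports. "The series", "measured", "known", "first", "only" and "open" are said of these compounds alone.

Compound 2, `COc1ccc(F)cc1CNCCCNc1ccnc2cc(-c3ccc(C(F)(F)F)cc3)ccc12`, stands in a physicochemical assay for acid dissociation, at 9.47, level with compound 1, `COc1ccc(F)cc1CNCCCNc1ccnc2cc(Cc3cccc(C(F)(F)F)c3)ccc12`, which in this assay gives 9.47. For the measured compounds named here, that pair is the only measured step here: no change at the digits printed from compound 1 to compound 2 (within the scatter). Compound 3, `COc1ccc(F)cc1CNCCCNc1ccnc2cc(Oc3ccccc3OC)ccc12`, carries the change (2-methoxyphenoxy in place of 4-(trifluoromethyl)phenyl on an aromatic carbon). This change sits on the same aromatic carbon as the measured step, which left the reading unchanged, so the step from this change is expected to stay within the scatter: no change at the digits printed from compound 2 to compound 3 (within the scatter). For compound 3 the estimated value is therefore 9.47, with a range from 9.1 to 9.8.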

Compound 3, acid dissociation constant: 9.28
Beside the measured number, compound 3's estimate is 0.19 log units above it; low and high end bracket the measured number.
By their numbers in this assay, from the lowest: compounds 3, 1 and 2 (each within the scatter of the next).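

In this assay, a third kind of group on this aromatic carbon gives a similar reading: swapping in 2-methoxyphenoxy gives a number 0.19 log units lower from compound 2 to compound 3 (within the scatter), and a number 0.19 log units lower from compound 1 to compound 3 (within the scatter). This holds even though 2-methoxyphenoxy carries hydrogen-bond acceptors and the two trifluoromethyl groups it replaces carry none. Nothing available here explains this reading.

The compounds shown leave open whether an amine, a carboxylic acid or a longer chain on this carbon would also stay within the scatter. They also do not show which proton in the molecule the reading reports.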